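This account rests on a few compounds, and the source may have more. Where it says the series, first, only, none or still open, it means among the compounds named here.

For the measured compounds named here, compound 2 `O=c1ccc(-c2ccc3cn[nH]c3c2)cn1Cc1cccc(Cl)c1` gives 40 nM in an assay for inhibition of MAP kinase-interacting serine/threonine-protein kinase 2 (Homo sapiens), read by luminescence and ADP-Glo, with a stated time of 2 h (on this read-out lower numbers stand for stronger inhibition and higher numbers for weaker inhibition), the lowest of the two numbers measured so far. Going by the values given here, compound 1 `Nc1cccc(Cn2cc(-c3ccc4cn[nH]c4c3)ccc2=O)c1` gives 84 nM in this assay, and the only measured step is a 2.1-fold lower number from compound 1 to compound 2 (0.32 log units; beyond the scatter). Compound 3 `O=c1ccc(-c2ccc3cn[nH]c3c2)cn1Cc1ccccc1Cl` has not yet been measured. Its change from compound 2 is 2-chlorophenyl in place of 3-chlorophenyl on a saturated chain carbon bound to an aromatic nitrogen. Among the compounds with values here, the measured step exchanges amino for chloro and says nothing about where the chlorine sits on the ring, so no measured step bears directly on this move, and the expected step in this assay is none beyond the scatter. Compound 3 is therefore estimated at 50 nM, between 20 nM and 150 nM. The expected step is a 1.3-fold higher number from compound 2 to compound 3 (0.10 log units; within the scatter).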

Compound 3, half-maximal inhibitory concentration: 78 nM
Beside the measured number, compound 3's estimate is 1.6-fold (0.19 log units) below it; measured number inside the range.
By their numbers in this assay, from the lowest: compounds 2, 3 and 1 (each within the scatter of the next, the first and the last beyond it).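

Exchanging 3-chlorophenyl for 2-chlorophenyl at this position gives a 2.0-fold higher number from compound 2 to compound 3 (0.29 log units; within the scatter) in this assay, so these two chlorine placements are not told apart here. The step to 2-chlorophenyl from 3-aminophenyl, a 1.1-fold lower number from compound 1 to compound 3 (0.03 log units; within the scatter), likewise separates neither group, although 3-chlorophenyl does stand apart from 3-aminophenyl. No measurement at hand explains these numbers. On these data alone, whether a carboxylic acid in place of the chlorine, or a longer chain leading to the ring, would give a clearly different number in this assay remains open.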